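The source may report more compounds than this note shows. Statements on the series, on what has been measured and on what is new or still open speak of the compounds shown alone.

Among the compounds with values here, in an assay for inhibition of Amine oxidase [flavin-containing] A (Rattus norvegicus) (on this read-out higher numbers stand for weaker inhibition and lower numbers for stronger inhibition), compound 3 `COc1cccc(COc2ccc(-c3nn(CCC#N)c(=S)o3)cc2)c1` gives 8100 nM, the second highest of the three numbers measured so far, though all three lie within the scatter of one another. Compound 1 `N#CCCn1nc(-c2ccc(OCc3cccc(Cl)c3)cc2)oc1=O` gives 7400 nM, and compound 2 `N#CCCn1nc(-c2ccc(OCc3ccc([N+](=O)[O-])cc3)cc2)oc1=O` gives 11000 nM. Compound 4 `COc1ccc(COc2ccc(-c3nn(CCC#N)c(=S)o3)cc2)cc1` differs from compound 3 in one place: 4-methoxyphenyl in place of 3-methoxyphenyl on a saturated chain carbon bound to an oxygen on an aromatic ring. Within the data shown here, the only measured step that touches this place is a 1.5-fold higher number from compound 1 to compound 2 (0.17 log units; within the scatter), which exchanged one aryl group for another on the same chain carbon and stayed within the scatter. The expectation for a 1.0-fold lower number from compound 3 to compound 4 (0.01 log units; within the scatter) is therefore a change no larger than the scatter, in no preferred direction. Compound 4 is estimated at 8000 nM, with a range from 3500 nM to 18000 nM.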

Compound 4, half-maximal inhibitory concentration: 4800 nM
The estimate for compound 4 lay 1.7-fold (0.22 log units) above the measured number; measured number inside the range.
By their numbers in this assay, from the lowest: compounds 4, 1, 3 and 2 (each within the scatter of the next, the first and the last beyond it).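

In this assay, the step with a 1.7-fold lower number from compound 3 to compound 4 (0.23 log units; within the scatter) comes from a swap that keeps the same atoms and joins them differently. Like the earlier exchange of one aryl group for another, it stays within the scatter, so the methoxy group's two placements cannot be told apart here. No available evidence bears on this result. The compounds shown leave open whether an amine or a carboxylic acid on this phenyl ring would take the number beyond the scatter. On these data alone, a longer chain between that ring and the oxygen remains equally open.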